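This account rests on a few compounds, and the source may have more. Where it says the series, first, only, none or still open, it means among the compounds named here.

Measured compounds in an ADME assay on L6 cells (Rattus norvegicus) for cytotoxicity; on this read-out lower numbers stand for stronger inhibition and higher numbers for weaker inhibition:
Compound 1 `CCN1CCN(CCN2CCC3(N4CCCC4)CC(c4ccccc4)C2C(c2ccccc2)C3)CC1` gives 53600 nM.
Compound 2 `CCN1CCN(CCN2CCC3(N4CCCCC4)CC(c4ccccc4)C2C(c2ccccc2)C3)CC1` gives 67500 nM.
Compound 3 `CCN1CCN(CCN2CCC3(N(C)C)CC(c4ccccc4)C2C(c2ccccc2)C3)CC1` gives 58000 nM.

Compound 1 gives the smallest of the three numbers in this assay, but only nominally: compound 3 sits nearest to it and compound 2 furthest, and both steps, a 1.1-fold higher number from compound 1 to compound 3 (0.03 log units; within the scatter) and a 1.3-fold higher number from compound 1 to compound 2 (0.10 log units; within the scatter), fall within the scatter, as does a 1.2-fold lower number from compound 2 to compound 3 (0.07 log units; within the scatter). The three measured compounds are therefore indistinguishable on this read-out.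

Compound 4 `c1ccc(C2CC3(N4CCCC4)CCN(CCN4CCCC4)C2C(c2ccccc2)C3)cc1` has not been measured. It differs from compound 1 in one place: pyrrolidin-1-yl in place of 4-ethylpiperazin-1-yl on a saturated chain carbon, two bonds along the chain from an amine nitrogen in a ring. The three measured steps all concern a different site, the substituent on a saturated ring carbon, and none of them touches the saturated chain carbon two bonds along the chain from an amine nitrogen in a ring. For the measured compounds named here, no measured step therefore bears directly on this change. What the measured compounds do show is that varying an amine substituent on this shared core left this assay unmoved beyond the scatter.

On that basis the estimated step of a 1.0-fold higher number from compound 1 to compound 4 (0.01 log units; within the scatter) is expected to stay within the scatter. Compound 4 is expected to give about 55000 nM in this assay. The expected range for compound 4 runs from 25000 nM to 120000 nM.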

Compound 4, half-maximal inhibitory concentration: 58200 nM
Estimate against measurement, compound 4: 1.1-fold (0.02 log units) below, within the range that was stated.
By their numbers in this assay, from the lowest: compounds 1, 3, 4 and 2 (each within the scatter of the next).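

Compound 4 is the first of these compounds to carry a change at the saturated chain carbon, two bonds along the chain from an amine nitrogen in a ring, since the earlier steps all concerned the substituent on a saturated ring carbon. In this assay, replacing 4-ethylpiperazin-1-yl with pyrrolidin-1-yl gives a 1.1-fold higher number from compound 1 to compound 4 (0.04 log units; within the scatter), so this place also stays within the scatter, even though the group goes from 8 heavy atoms and 2 hydrogen-bond acceptors to 5 heavy atoms and 1 hydrogen-bond acceptor. No evidence is available that accounts for this result.

On these data alone, whether a morpholin-4-yl group or a carboxylic acid at this place, or a chain longer than 2-(pyrrolidin-1-yl)ethyl, would stay within the scatter remains open. The compounds shown also leave open whether any change at this place or on the saturated ring carbon would move this read-out beyond the scatter, as all of the steps shown lie within it.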